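Acetamido for Nitrooxy on the Sulfonyl Aryl Ring

A few compounds are considered here, and "the series" means these few. Any claim that something is new, unique, unknown or untested is made for them only; others in the source may bear on it.

Going by the values given here, the series shares a bis(fluorobenzylidene)piperidinone core carrying an arylsulfonyl group, and all members so far have been run in a functional assay on SMMC-7721 cells (Homo sapiens) for cytotoxicity, read by MTT assay, with a stated time of 24 h; a higher number here means a weaker inhibitor, a lower number a stronger inhibitor. Compound 1 `Cc1ccc(S(=O)(=O)N2C/C(=C\c3ccccc3F)C(=O)/C(=C/c3ccccc3F)C2)cc1` gives 4100 nM. Compound 2 `CC(=O)Nc1ccc(S(=O)(=O)N2C/C(=C\c3ccccc3F)C(=O)/C(=C/c3ccccc3F)C2)cc1` gives 7500 nM. Compound 3 `O=C1/C(=C/c2ccc(F)cc2)CN(S(=O)(=O)c2ccc(O[N+](=O)[O-])cc2)C/C1=C\c1ccc(F)cc1` gives 5000 nM, which places it second highest of the three numbers, with its nearest neighbour compound 1 and its furthest compound 2, both within the scatter of it; the three measured values therefore cannot be ordered.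

Compound 4 `CC(=O)Nc1ccc(S(=O)(=O)N2C/C(=C\c3ccc(F)cc3)C(=O)/C(=C/c3ccc(F)cc3)C2)cc1` has not yet been measured. It differs from compound 3 by acetamido in place of nitrooxy on an aromatic carbon. Among the compounds with values here, the only measured step on this part of the molecule is a 1.8-fold higher number from compound 1 to compound 2 (0.26 log units; within the scatter), which swaps methyl for acetamido; the step from compound 3 to compound 4 instead replaces nitrooxy, and no measured pair shows that exchange. Given that the one comparable step stays within the scatter, and that all three measured values sit within the scatter of one another, no step beyond the scatter is expected here; if anything, a slightly higher number in this assay, in line with what compound 2 shows against compound 1.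

Compound 4 is therefore expected to give about 6000 nM in this assay, within a range of 3000 nM to 12000 nM, an estimated step of a 1.2-fold higher number from compound 3 to compound 4 (0.08 log units; within the scatter).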

Compound 4, half-maximal inhibitory concentration: 9800 nM
Estimate against measurement, compound 4: 1.6-fold (0.21 log units) below; the measured number falls inside the stated range.
By their numbers in this assay, from the lowest: compounds 1, 3, 2 and 4 (each within the scatter of the next, the first and the last beyond it).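

Working notes on the aromatic carbon para to a large group: in this assay, the change from 4-(nitrooxy)phenyl to 4-acetamidophenyl gives a 2.0-fold higher number from compound 3 to compound 4 (0.29 log units; within the scatter) and is the first reading of an exchange that removes nitrooxy. The two groups have the same heavy-atom count but differ in their hydrogen-bond donor and acceptor counts, so this step shows that such a change in those counts at this position need not carry the number beyond the scatter, and the earlier step, a 1.8-fold higher number from compound 1 to compound 2 (0.26 log units; within the scatter), likewise stays within it. No measurement available here bears on the cause of either step.

Neither step at this position goes beyond the scatter, so the compounds shown do not establish whether any replacement here can shift the number in this cell assay, and a free amine or a carboxylic acid on the same aromatic carbon would test that. A longer acyl chain in place of the acetyl part of acetamido would show whether the position stays this insensitive as the group grows beyond the size seen so far.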